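The source may hold more compounds than are shown below. What is called first, only, known or untested is meant among the compounds shown, and "the series" means these compounds.

In a functional assay on HepG2 cells (Homo sapiens) for antiproliferative activity, read by MTT assay, with a stated time of 3 days (on this read-out lower numbers stand for stronger inhibition and higher numbers for weaker inhibition), compound 2 `CCCCCCC#Cc1cn(C/C=C/CN2C(=O)c3ccccc3C2=O)c(=O)[nH]c1=O` gives 14000 nM and sits close to compound 3 `CCCCCc1ccc(C#Cc2cn(C/C=C\CN3C(=O)c4ccccc4C3=O)c(=O)[nH]c2=O)cc1` at 18000 nM as these two values lie within the usual scatter of each other. Compound 1 `Cc1ccc(C#Cc2cn(C/C=C\CN3C(=O)c4ccccc4C3=O)c(=O)[nH]c2=O)cc1` stands apart at 68000 nM with a clearly higher number than compound 2.

Compound 4 `CCCCCC#Cc1cn(C/C=C/CN2C(=O)c3ccccc3C2=O)c(=O)[nH]c1=O` has not been measured yet. Its change from compound 2 is small (hydrogen in place of methyl on a saturated chain carbon, five bonds along the chain from a triple-bonded carbon) and amounts to hydrogen in place of methyl on a saturated chain carbon, five bonds along the chain from a triple-bonded carbon.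

Among the measured compounds shown here, only one measured step bears on this, and only loosely. The step of a 3.8-fold lower number from compound 1 to compound 3 (0.58 log units; beyond the scatter) came with butyl in place of hydrogen on a saturated chain carbon bound to an aromatic carbon. There, adding to a chain went with a lower number, so trimming a chain might nudge the number up. However, losing a methyl is a much smaller change than adding a butyl, and compounds 1 and 3 also differ from compound 2 elsewhere, so this step offers only a weak guide.

The estimated step (a 1.2-fold higher number from compound 2 to compound 4 (0.08 log units; within the scatter)) is a slight rise in this assay that stays within the scatter. Compound 4 is estimated at 17000 nM with an expected range from 8500 nM to 36000 nM in this measurement.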

Compound 4, half-maximal inhibitory concentration: 9000 nM
Compound 4: the middle estimate sits 1.9-fold (0.28 log units) above what was measured; the measured number falls inside the stated range.
By their numbers in this assay, from the lowest: compounds 4, 2 and 3 (each within the scatter of the next); then compound 1.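

In this assay, among the compounds shown here, the step of a 1.6-fold lower number from compound 2 to compound 4 (0.19 log units; within the scatter) is the first measured change at this position, with hydrogen in place of methyl on a saturated chain carbon, five bonds along the chain from a triple-bonded carbon, and it lies within the scatter, so compound 2 and compound 4 cannot be told apart on this read-out. For the compounds shown here, the only earlier step, a 3.8-fold lower number from compound 1 to compound 3 (0.58 log units; beyond the scatter), lay beyond the scatter, but it involved butyl on a saturated chain carbon bound to an aromatic carbon, a different place and a much larger change, so it said nothing about this small trim of the chain. Nothing shown here offers an explanation for the result.

Still open, going by these compounds, is whether a much longer chain, or an amine or a hydroxyl group in place of the methyl, would move the number beyond the scatter from compound 2 in this assay. Going by these compounds alone, also open is whether the same trim would behave alike with the other double-bond geometry, the one carried by compound 1 and compound 3.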